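This account rests on a few compounds, and the source may have more. Where it says the series, first, only, none or still open, it means among the compounds named here.

Working notes on the series. Compound 1 `CCCN1C/C(=C\c2ccc(OC)c(OC)c2)C(=O)/C(=C/c2ccc(OC)c(OC)c2)C1` in a functional assay on A549 cells (Homo sapiens) for cytotoxicity, read by MTT assay, with a stated time of 72 h (a higher number here means a weaker inhibitor, a lower number a stronger inhibitor), gives 4200 nM. Going by the values given here, compound 3 `COc1ccc(/C=C2\CN(C)C/C(=C\c3ccc(OC)c(OC)c3)C2=O)cc1OC` gives 1300 nM in this assay, and the step of a 3.2-fold lower number from compound 1 to compound 3 (0.51 log units; beyond the scatter) is the only single-point change so far measured. Compound 2 `CCC(=O)N1C/C(=C\c2cc(OC)c(OC)c(OC)c2)C(=O)/C(=C/c2cc(OC)c(OC)c(OC)c2)C1` gives 800 nM and holds the lowest of the three numbers: its gap to compound 3 lies within the scatter, its gap to compound 1 beyond it.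

Compound 4 `CCN1C/C(=C\c2cc(OC)c(OC)c(OC)c2)C(=O)/C(=C/c2cc(OC)c(OC)c(OC)c2)C1` is not yet measured. It differs from compound 2 by ethyl in place of propanoyl on an amine nitrogen in a ring. Among the compounds with values here, no measured step covers this change: the one step on record, from compound 1 to compound 3, alters the alkyl group on the same ring nitrogen and was modest in size, whereas here an amide becomes an amine and the two compounds with amine nitrogens, compound 1 and compound 3, both sit at higher numbers than compound 2 while also carrying a different methoxy pattern on the aryl rings. On that basis a moderate rise is expected, of about a 2.0-fold higher number from compound 2 to compound 4 (0.30 log units; within the scatter), with wide uncertainty. Compound 4 is estimated at 1600 nM in this assay, with a range from 500 nM to 5000 nM.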

Compound 4, half-maximal inhibitory concentration: 4200 nM
Beside the measured number, compound 4's estimate is 2.6-fold (0.42 log units) below it; low and high end bracket the measured number.
By their numbers in this assay, from the lowest: compounds 2 and 3 (each within the scatter of the next); then compounds 1 and 4 (each within the scatter of the next).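

The aryl groups of compound 2 and compound 4 are the same, so in this assay the change of propanoyl to ethyl on the amine nitrogen in the ring can be read on its own, and it gives a 5.3-fold higher number from compound 2 to compound 4 (0.72 log units; beyond the scatter). Going by these compounds alone, this is the first step on record that removes a carbonyl from this nitrogen, whereas a 3.2-fold lower number from compound 1 to compound 3 (0.51 log units; beyond the scatter) only exchanges one alkyl group for another and belongs to compounds with a different set of aryl groups; the group on this nitrogen therefore shifts the number beyond the scatter in both aryl settings, and the propanoyl compound sits on the lower side of its step. No measurement on hand accounts for this step.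

Propanoyl and ethyl differ both in the carbonyl and in heavy atom count, so the compounds shown do not separate these two changes, and an acetyl group on the same nitrogen, with the aryl groups of compound 2, would bear directly on that question. As far as these compounds go, whether a longer acyl chain such as butanoyl, or a sulfonyl group, behaves like propanoyl also remains open.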